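A few compounds are considered here, and "the series" means these few. Any claim that something is new, unique, unknown or untested is made for them only; others in the source may bear on it.

In an ADME assay on HEK293 cells (Homo sapiens) for cytotoxicity, read by CCK-8 assay, with a stated time of 48 h (on this read-out lower numbers stand for stronger inhibition and higher numbers for weaker inhibition), compound 1 `COc1ccc(/C=C\c2cc(OC)c(OC)c(OC)c2)cc1OCc1ccc(CN2C[C@H](O)C[C@@H]2C(=O)O)cc1` gives > 50000 nM, which is a limit of the assay and not a number. Compound 2 `COc1ccc(/C=C\c2cc(OC)c(OC)c(OC)c2)cc1OCc1ccc(CN[C@H](C(=O)O)[C@H](C)O)cc1` gives > 50000 nM, again a limit. Compound 2 thus stands at the limit of > 50000 nM in this assay, at which 2 of the 2 values shown sit, and no number places it. Compound 3 `COc1ccc(/C=C\c2cc(OC)c(OC)c(OC)c2)cc1OCc1ccc(CO)cc1` carries hydroxy in place of (1-carboxy-2-hydroxypropyl)amino on a saturated chain carbon bound to an aromatic carbon. Within the data shown here, the only measured step touching this place is a step that the two limits leave unreadable from compound 1 to compound 2, and it yields no size to carry over. In this assay a shift towards stronger inhibition is nevertheless expected, with compound 3 possibly remaining at the limit. The step expected is an at least 6.2-fold lower number from compound 2 to compound 3 (0.79 log units; beyond the scatter). For compound 3 the estimated value is 8000 nM, with an expected range from 500 nM to 50000 nM.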

Compound 3, half-maximal inhibitory concentration: 37000 nM
For compound 3 the middle estimate is 4.6-fold (0.67 log units) below the measured one; the measured number falls inside the stated range.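

In this assay, among these compounds, compound 3 gives 37000 nM, the first actual number at this place on a saturated chain carbon bound to an aromatic carbon. Hydroxy in place of (1-carboxy-2-hydroxypropyl)amino gives an at least 1.3-fold lower number from compound 2 to compound 3 (0.13 log units; that floor lies within the scatter), and hydroxy in place of 2-carboxy-4-hydroxypyrrolidin-1-yl gives an at least 1.3-fold lower number from compound 1 to compound 3 (0.13 log units; that floor lies within the scatter). Compounds 1 and 2 each remain at a limit of the assay, not a number, so these steps are floors only: the limit of > 50000 nM in this assay, at which 2 of the 3 values shown sit.

From the compounds shown here alone, the true size of both steps remains open, and the step between compounds 1 and 2 cannot be read. Also open, going by these compounds, is whether a simple amine or a carboxylic acid alone at this place would give a number or stay at the limit.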